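The source may report more compounds than this note shows. Statements on the series, on what has been measured and on what is new or still open speak of the compounds shown alone.

Measured compounds in an assay on HEK293 cells for positive allosteric modulation of metabotropic glutamate receptor 3 (Rattus norvegicus), read by thallium flux, with a stated time of 2.5 min; a lower number here means a smaller maximal response, a higher number a larger maximal response:
Compound 1, `COC(=O)c1ccc(OCCCCOc2ccc(C(=O)CC3CCCC3)c(O)c2C)cc1`, gives 22%.
Compound 2, `Cc1c(OCCCCOc2cccc(C(=O)O)c2)ccc(C(=O)CC2CCCC2)c1O`, gives 92.9%.
Compound 3, `COC(=O)c1ccc(OCCCCOc2ccc(C(=O)CC(C)C)c(O)c2C)cc1`, gives 22.7%.

Compound 3 stands second highest of these three; compound 1 sits a number 0.7 percentage points higher from compound 1 to compound 3 (within the scatter) from it, within the scatter, while compound 2 lies well above it, beyond the scatter. Compound 4, `Cc1c(OCCCCOc2ccc(F)c(C(=O)O)c2)ccc(C(=O)CC(C)C)c1O`, differs from compound 3 in one place: 3-carboxy-4-fluorophenyl in place of 4-(methoxycarbonyl)phenyl on an oxygen on a saturated carbon. The measured step that bears on this is a number 70.9 percentage points higher from compound 1 to compound 2 (beyond the scatter), where a carboxylic acid replaced a methyl ester on the oxygen on a saturated carbon; the swap of cyclopentyl for isopropyl, a number 0.7 percentage points higher from compound 1 to compound 3 (within the scatter), changed little. A large rise in this assay is therefore expected, a number 62.3 percentage points higher from compound 3 to compound 4 (beyond the scatter), the added fluorine being the open question. Compound 4 is estimated at 85%, between 60% and 100%.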

Compound 4, largest response reached (reported as percent of maximum), in percent of the reference or control that the assay uses: 81.7%
The estimate for compound 4 lay 3.3 percentage points above the measured number; the range from low to high includes it.
By their numbers in this assay, from the lowest: compounds 1 and 3 (each within the scatter of the next); then compound 4; then compound 2.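

The large rise seen with the cyclopentyl compounds (a number 70.9 percentage points higher from compound 1 to compound 2 (beyond the scatter)) also appears with isopropyl on the saturated chain carbon bound to a carbonyl carbon: in this assay, 3-carboxy-4-fluorophenyl in place of 4-(methoxycarbonyl)phenyl gives a large step (a number 59 percentage points higher from compound 3 to compound 4 (beyond the scatter)). The gain at this oxygen-bound position therefore holds across both of these groups, and it survives a fluorine on the ring. Nothing shown here gives a reason for this rise. The compounds leave open what the fluorine adds on its own, and whether a tetrazole or a primary amide could stand in for the carboxylic acid.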